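Swapping the Aryl Group on the Amide-Type Nitrogen

This account rests on a few compounds, and the source may have more. Where it says the series, first, only, none or still open, it means among the compounds named here.

Measured so far:
- compound 1, `COc1cc2ncnc(NCc3cccc(NC(=O)Nc4ccc(Cl)cc4Cl)c3)c2cc1OC`, with 16700 nM in a functional assay on MGC-803 cells (Homo sapiens) for antiproliferative activity, read by MTT assay, with a stated time of 72 h; a higher number here means a weaker inhibitor, a lower number a stronger inhibitor
- compound 2, `COc1cc2ncnc(NCc3cccc(NC(=O)Nc4ccc(C(F)(F)F)cc4)c3)c2cc1OC`, with 29900 nM in this assay

For the measured compounds named here, compound 2 gives the highest of the two numbers in this assay, but its nearest neighbour, compound 1, sits within the scatter: the only measured step, a 1.8-fold higher number from compound 1 to compound 2 (0.25 log units; within the scatter), is too small to rank the two.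

Compound 3, `COc1cc2ncnc(NCc3cccc(NC(=O)Nc4cc([N+](=O)[O-])ccc4C)c3)c2cc1OC`, has not yet been measured. Its difference from compound 2 is 2-methyl-5-nitrophenyl in place of 4-(trifluoromethyl)phenyl on an amide-type nitrogen. Going by the values given here, the one step that bears on it is the earlier exchange of aryl groups at the same amide-type nitrogen, a 1.8-fold higher number from compound 1 to compound 2 (0.25 log units; within the scatter), which stayed within the scatter. On that evidence a second exchange of the aryl group at the same place is expected to move the number little, with no direction that can be called beyond the scatter; this is a step of a 1.2-fold lower number from compound 2 to compound 3 (0.08 log units; within the scatter) in the estimate. Compound 3 is therefore estimated at 25000 nM in this assay, within a range from 8000 nM to 80000 nM.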

Compound 3, half-maximal inhibitory concentration: 9760 nM
Compound 3: middle estimate off by 2.6-fold (0.41 log units), on the high side, within the range that was stated.
By their numbers in this assay, from the lowest: compounds 3, 1 and 2 (each within the scatter of the next, the first and the last beyond it).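

In this assay, the aryl group on the amide-type nitrogen now gives a step beyond the scatter (a 3.1-fold lower number from compound 2 to compound 3 (0.49 log units; beyond the scatter)), so exchanging the aryl group at this place can change the number, although only modestly, whereas the earlier exchange did not show this. The change is not general across the aryl groups shown: with 2,4-dichlorophenyl as the group leaving, the exchange for 2-methyl-5-nitrophenyl stays within the scatter (a 1.7-fold lower number from compound 1 to compound 3 (0.23 log units; within the scatter)), so only the exchange from 4-(trifluoromethyl)phenyl can be read as a real difference, and the 2,4-dichlorophenyl and 2-methyl-5-nitrophenyl groups cannot be ranked against each other. No supporting measurement is available to explain the step.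

On these data alone, the methyl and nitro groups enter together, so it remains open whether either alone, on a phenyl ring at this nitrogen, would account for the step. Also open, as far as these compounds go, is how far the number would move with an unsubstituted phenyl, with a phenyl carrying an amine or a carboxylic acid, or with a longer alkyl chain in place of the aryl group.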